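The source may report more compounds than this note shows. Statements on the series, on what has been measured and on what is new or still open speak of the compounds shown alone.

Compound 1, `COc1ccc(-c2nn3cc(-c4cccc(N)c4)nc3s2)cc1OC`, in a functional assay on L1210 cells (Mus musculus) for inhibition, read by cell counting, with a stated time of 2 days (on this read-out higher numbers stand for weaker inhibition and lower numbers for stronger inhibition), gives 16000 nM.
Compound 2, `COc1ccc(-c2nn3cc(-c4cccc(N)c4)nc3s2)cc1`, in this assay gives >= 250000 nM, which is a limit of the assay and not a measured number.
Compound 3, `C=C(Br)C(=O)Nc1cccc(-c2cn3nc(-c4ccc(OC)cc4)sc3n2)c1`, in this assay gives 940 nM.

Compound 2 therefore stands only at the limit of >= 250000 nM in this assay, at which 1 of the 3 values shown sits; where its true number lies is not known. Compound 4, `Nc1cccc(-c2cn3nc(-c4ccc(F)cc4)sc3n2)c1`, differs from compound 2 by fluoro in place of methoxy on an aromatic carbon. Going by the values given here, no measured pair shows this exact exchange. The nearest evidence is an at least 15-fold higher number from compound 1 to compound 2 (1.19 log units; beyond the scatter), which removed a methoxy and weakened inhibition by a large margin, and an at least 260-fold lower number from compound 2 to compound 3 (2.42 log units; beyond the scatter), which attached a reactive group and strengthened it by a large margin; the second step changes a different part of the molecule and says little about a fluoro for methoxy swap. Since the methoxy that is lost in compound 4 is the same kind of group whose loss weakened compound 1, compound 4 is expected to remain a weak inhibitor, with an at least 1.6-fold lower number from compound 2 to compound 4 (0.22 log units; that floor lies within the scatter) as the expected step in this assay. Compound 4 is therefore estimated at 150000 nM, with a range from 30000 nM to 400000 nM, and a fair chance that only a limit is reported.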

Compound 4, half-maximal inhibitory concentration: >= 250000 nM
Compound 4: no number, only a limit; the forecaster's own chance of this, stated with the estimate: 50%; middle value at least 1.6-fold (0.22 log units) from the limit.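

In this assay compound 4 gives >= 250000 nM, which is a limit of the assay and not a measured number. Going by these compounds alone, compound 2 and compound 4 sit at the same limit, so no step between them can be read: the limit of >= 250000 nM in this assay, at which 2 of the 4 values shown sit. Where the true numbers of compound 2 and compound 4 lie, and how fluoro in place of methoxy changes inhibition, stay open.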